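The source may report more compounds than this note shows. Statements on the series, on what has been measured and on what is new or still open speak of the compounds shown alone.

Measured so far:
compound 1 `O=C(NO)c1ccc(N(Cc2ccc(C(F)(F)F)cc2)C(=O)CN(Cc2ccccc2C(F)(F)F)S(=O)(=O)c2ccc(F)c(F)c2)cc1` — > 1000 nM
compound 2 `O=C(NO)c1ccc(N(Cc2ccc(C(F)(F)F)cc2)C(=O)CN(Cc2ccccc2C(F)(F)F)S(=O)(=O)c2ccc(F)cc2)cc1` — > 1000 nM

In an assay on Sf9 cells for inhibition of histone deacetylase 8 (Homo sapiens), read by mobility shift assay (on this read-out lower numbers stand for stronger inhibition and higher numbers for weaker inhibition), compound 2 gives > 1000 nM, which is a limit of the assay and not a number. Compound 1 likewise gives > 1000 nM, again a limit. The step that the two limits leave unreadable from compound 1 to compound 2 therefore cannot be read, since both values sit at the limit of > 1000 nM in this assay, at which 2 of the 2 values shown sit.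

Compound 3 `O=C(NO)c1ccc(N(Cc2ccc(C(F)(F)F)cc2)C(=O)CN(Cc2ccccc2C(F)(F)F)S(=O)(=O)c2ccc(F)cc2F)cc1` differs from compound 2 by fluoro in place of hydrogen on an aromatic carbon. Within the data shown here, no measured step with a readable size bears on this change. The step that the limit leaves unreadable from compound 2 to compound 3 is expected to be none beyond the scatter. Compound 3 is estimated at 2500 nM, with a range from 700 nM to 15000 nM, most likely again as a limit.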

Compound 3, half-maximal inhibitory concentration: > 1000 nM
Compound 3 ended at the assay's limit; the forecaster's own chance of this, stated with the estimate: 80%; the middle value is on the limit's open side.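

In this assay no step among compound 1, compound 2 and compound 3 can be read, because all three values are limits of the assay and not numbers: the limit of > 1000 nM in this assay, at which 3 of the 3 values shown sit.

On these data alone, whether 4-fluorophenyl, 3,4-difluorophenyl and 2,4-difluorophenyl on the sulfonyl sulfur differ in inhibition stays open.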